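A few compounds are considered here, and "the series" means these few. Any claim that something is new, unique, unknown or untested is made for them only; others in the source may bear on it.

Measured in a functional assay on MCF7 cells (Homo sapiens) for inhibition, read by fluorescence, with a stated time of 72 h; on this read-out lower numbers stand for stronger inhibition and higher numbers for weaker inhibition:
- compound 1 `CCCn1cnc2c(NC(=N)N)nc(N)nc21`: 36500 nM
- compound 2 `CC(C)Cn1cnc2c(NC(=N)N)nc(N)nc21`: 96600 nM
- compound 3 `N=C(N)Nc1nc(N)nc2c1ncn2CCO`: > 100000 nM, which is a limit

Compound 3 has no exact number, only (the limit of > 100000 nM in this assay, at which 1 of the 3 values shown sits).

Compound 4 `N=C(N)Nc1nc(N)nc2c1ncn2CCN` has amino in place of hydroxy on a saturated chain carbon, two bonds along the chain from an aromatic nitrogen.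

For the measured compounds named here, no measured step makes this exchange. The closest evidence is at the same chain: an at least 2.7-fold higher number from compound 1 to compound 3 (0.43 log units; beyond the scatter), and an at least 1.0-fold higher number from compound 2 to compound 3 (0.01 log units; that floor lies within the scatter). Branching gave a 2.6-fold higher number from compound 1 to compound 2 (0.42 log units; beyond the scatter). These steps show weak values throughout, so no step beyond the scatter is expected in this assay.

The expected step is an at least 1.2-fold lower number from compound 3 to compound 4 (0.09 log units; that floor lies within the scatter).

For compound 4 the estimate is 80000 nM, with an expected range of 25000 nM to 200000 nM.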

Compound 4, half-maximal inhibitory concentration: > 100000 nM
Compound 4 was reported as a limit; the forecaster's own chance of this, stated with the estimate: 50%; at least 1.2-fold (0.09 log units) between middle value and limit.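

In this assay compound 4 gives > 100000 nM, which is a limit, and the exchange of hydroxy for amino cannot be read, since compound 3 is a limit too. Against the alkyl chains, the result shows an at least 2.7-fold higher number from compound 1 to compound 4 (0.43 log units; beyond the scatter) and an at least 1.0-fold higher number from compound 2 to compound 4 (0.01 log units; that floor lies within the scatter). So a second chain ending in a group other than carbon gives no exact number, and these comparisons remain floors: the limit of > 100000 nM in this assay, at which 2 of the 4 values shown sit.

Still open, on these data alone, is whether a longer chain ending in an amine, or a carboxylic acid on this chain, would give an exact number in this assay.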